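From phenoxy to methyl: the step to compound 4

The source may report more compounds than this note shows. Statements on the series, on what has been measured and on what is new or still open speak of the compounds shown alone.

In a functional assay on HT-29 cells (Homo sapiens) for inhibition, read by sulforhodamine B assay, with a stated time of 48 h (a lower number here means a stronger inhibitor of growth, a higher number a weaker inhibitor of growth), compound 1 `c1ccc(Oc2ccc(NC3=NCCO3)cc2)cc1` gives 2000 nM, compound 2 `O=C(CCl)NC(=O)Nc1ccc(OC2CCCCC2)cc1` gives 3100 nM and compound 3 `O=C(CCl)NC(=O)Nc1ccc(Oc2ccccc2)cc1` gives 3600 nM. Compound 3 stands within the scatter of both others, as a 1.8-fold higher number from compound 1 to compound 3 (0.26 log units; within the scatter) shows. Compound 4 `Cc1ccc(NC(=O)NC(=O)CCl)cc1` has methyl in place of phenoxy on an aromatic carbon. The nearest measured change, a 1.2-fold higher number from compound 2 to compound 3 (0.06 log units; within the scatter), is phenyl in place of cyclohexyl on the oxygen and lies within the scatter. Going by the values given here, both of those compounds keep a ring on that oxygen, so no measured step covers its loss, and the expectation is weakly grounded. A moderate move to a higher number is expected, estimated as a 1.9-fold higher number from compound 3 to compound 4 (0.29 log units; within the scatter). For compound 4 the estimate is 7000 nM, with an expected range of 3000 nM to 20000 nM.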

Compound 4, concentration for 50% growth inhibition: 10000 nM
The estimate for compound 4 lay 1.4-fold (0.15 log units) below the measured number; the measured number falls inside the stated range.
By their numbers in this assay, from the lowest: compounds 1, 2 and 3 (each within the scatter of the next); then compound 4.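

In this assay, going by these compounds alone, losing the ring on the oxygen gives the first steps beyond the scatter: methyl in place of phenoxy gives a 2.8-fold higher number from compound 3 to compound 4 (0.44 log units; beyond the scatter), and methyl in place of cyclohexyloxy gives a 3.2-fold higher number from compound 2 to compound 4 (0.51 log units; beyond the scatter). Phenyl and cyclohexyl on the oxygen read alike, so the ring's presence matters more here than its aromatic or saturated form. No measured evidence bears on the reason for these steps.

Methyl removes the oxygen and the ring together, so their separate shares stay open. Methoxy, which keeps the oxygen without the ring, and benzyl, which keeps a ring without the oxygen, would divide the two.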